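The compounds below may be only part of what the source reports. "The series", "measured", "known", "first", "only" and "open" are said of these compounds alone.

Measured in an ADME assay (liver, Mus musculus) for metabolic stability, using microsomes; on this read-out lower numbers stand for a shorter-lived compound and higher numbers for a longer-lived compound:
- Compound 1 `C=CC(=O)Nc1cccc(CNc2nc(Nc3cn(C)nc3C)ncc2Cl)c1`: 0.138 h
- Compound 2 `C=CC(=O)Nc1cccc(CNc2nc(Nc3cnn(C4CCOCC4)c3)ncc2Cl)c1`: 0.025 h

Compound 2, at 0.025 h, holds the lower of the two numbers. Compound 1, at 0.138 h, stands higher, and that gap lies beyond the usual scatter of repeated measurements.

Compound 3 `C=CC(=O)Nc1cccc(CNc2nc(Nc3cnn(CCOC)c3)ncc2Cl)c1` has not yet been measured. It keeps the frame of compound 2 but carries 2-methoxyethyl in place of oxan-4-yl on an aromatic nitrogen. For the measured compounds named here, no two measured compounds differ in one place only, so the data give no direct guide to the size of such a step. Both groups contain oxygen, so only a small upward move, within the scatter, is expected in this assay. The expected step is a 1.4-fold higher number from compound 2 to compound 3 (0.15 log units; within the scatter). For compound 3 the estimate is 0.035 h, with an expected range from 0.015 h to 0.08 h.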

Compound 3, half-life: 0.055 h
Compound 3: middle estimate off by 1.6-fold (0.20 log units), on the low side; the measured number falls inside the stated range.
By their numbers in this assay, from the lowest: compound 2; then compound 3; then compound 1.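

In this assay, replacing the ring of oxan-4-yl with the open 2-methoxyethyl chain on this aromatic nitrogen gives a 2.2-fold higher number from compound 2 to compound 3 (0.34 log units; beyond the scatter), so the position responds even when the oxygen and the single hydrogen-bond acceptor stay. The change does not reach the level of the 1,3-dimethyl-1H-pyrazol-4-yl group, since exchanging it for 1-(2-methoxyethyl)-1H-pyrazol-4-yl gives a 2.5-fold lower number from compound 1 to compound 3 (0.40 log units; beyond the scatter). Nothing measured here accounts for either step.

Still open, as far as these compounds go, is how a plain propyl chain, or a chain ending in an amine, would compare with 2-methoxyethyl on this nitrogen. Such compounds could show whether the oxygen in the chain matters for half-life at all, or whether the absence of the ring is what counts.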